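Moving a Hydroxyl Around One Ring on Two Cores

This account rests on a few compounds, and the source may have more. Where it says the series, first, only, none or still open, it means among the compounds named here.

Of the compounds shown here, three built on two closely related cores have been measured in a functional assay on T47D cells (Homo sapiens) for inhibition; a lower number here means a stronger inhibitor, a higher number a weaker inhibitor. Compound 1 `Oc1cccc(-c2cc(-c3ccc(F)cc3)cc(-c3cccc(O)c3)n2)c1` gives 6870 nM, and compound 2 `Oc1ccc(-c2cc(-c3ccc(F)cc3)cc(-c3cccc(O)c3)n2)cc1` gives 5000 nM. The change from compound 1 to compound 2 is 4-hydroxyphenyl in place of 3-hydroxyphenyl on an aromatic carbon, and the step it made was a 1.4-fold lower number from compound 1 to compound 2 (0.14 log units; within the scatter). Compound 3 `Oc1cccc(-c2cc(-c3cccc(OC(F)(F)F)c3)cc(-c3ccccc3O)n2)c1` gives 5390 nM; the difference between the core of compound 3 and the core of compound 1 is not broken down here. Compound 4 `Oc1ccc(-c2cc(-c3cccc(OC(F)(F)F)c3)cc(-c3ccccc3O)n2)cc1` has not yet been measured. Compound 4 differs from compound 3 by 4-hydroxyphenyl in place of 3-hydroxyphenyl on an aromatic carbon, the same kind of change as that from compound 1 to compound 2, though not the same: in the first pair the place is meta to a 3-hydroxyphenyl group and meta to a 4-fluorophenyl group, whereas in the second it is meta to a 2-hydroxyphenyl group and meta to a large group. Because the earlier step of a 1.4-fold lower number from compound 1 to compound 2 (0.14 log units; within the scatter) stayed within the scatter, the same kind of change on the core of compound 3 is expected to stay small as well. Compound 4 is therefore expected to show a 1.3-fold lower number from compound 3 to compound 4 (0.11 log units; within the scatter), with an estimate of 4200 nM in this assay and a likely range from 2000 nM to 8500 nM.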

Compound 4, half-maximal inhibitory concentration: > 50000 nM
Compound 4: only a limit was reported (the forecaster's own chance of this, stated with the estimate: 3%); at least 11-fold (1.07 log units) between middle value and limit.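

In this assay compound 4 is reported only as a limit (> 50000 nM). Even so, 4-hydroxyphenyl in place of 3-hydroxyphenyl gave an at least 9.2-fold higher number from compound 3 to compound 4 (0.96 log units; beyond the scatter) on this core, so a change that stayed within the scatter on the core of compound 1 did not carry over unchanged to the core of compound 3: the same change on two cores in this assay, a 1.4-fold lower number (0.14 log units; within the scatter) from compound 1 to compound 2 and an at least 9.2-fold higher number (0.96 log units; beyond the scatter) from compound 3 to compound 4, at least 12-fold (1.10 log units) apart, beyond the scatter of two such steps

This shows that, in this series, the result of moving the hydroxyl on this ring depends on the rest of the molecule, but it does not show why, and the true size of the step stays unknown, since one end of it is a limit.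

The two cores differ in more than one place, so the compounds shown cannot tell whether the 2-hydroxyphenyl group or the large group matters for this difference. Also open, on these data alone, is how a carboxylic acid or an amine in place of the hydroxyl on the moved ring would read in this assay on either core.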